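Dropping a Methyl from the Benzyl Amide

The compounds below may be only part of what the source reports. "The series", "measured", "known", "first", "only" and "open" are said of these compounds alone.

The two compounds measured here share one core and differ in two places at once, so no single change can be read from them. In a functional assay on QGY7701 cells (Homo sapiens) for cytotoxicity, read by MTT assay, with a stated time of 24 h (on this read-out higher numbers stand for weaker inhibition and lower numbers for stronger inhibition), compound 1 `C=CC1=C(C(=O)NCc2ccc(C)cc2)C(c2ccc(F)cc2)OC1` gives 62100 nM, the higher of the two numbers and therefore the weaker cytotoxic effect. Compound 2 `C=CC1=C(C(=O)NC2CCCCC2)C(c2ccc(OC)c(OC)c2)OC1` gives 7490 nM in this assay, a markedly lower number; the gap between compound 1 and compound 2 lies beyond the usual scatter, but since the two structures differ both in the amide substituent and in the aryl group, nothing can be attributed to either change alone.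

Compound 3 `C=CC1=C(C(=O)NCc2ccccc2)C(c2ccc(F)cc2)OC1` is compound 1 with a single alteration: hydrogen in place of methyl on an aromatic carbon, that is, 4-methylbenzyl becomes benzyl. Among the compounds with values here, no measured pair shows this change, so there is no direct guide. A change this small, at the far end of the amide substituent, is expected to move the number little, in either direction or not beyond the scatter; the step from compound 1 to compound 3 is estimated as a 1.0-fold lower number from compound 1 to compound 3 (0.01 log units; within the scatter). Compound 3 is accordingly expected to give about 60000 nM in this assay, within a range of 20000 nM to 160000 nM.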

Compound 3, half-maximal inhibitory concentration: 67600 nM
The estimate for compound 3 lay 1.1-fold (0.05 log units) below the measured number; the range from low to high includes it.
By their numbers in this assay, from the lowest: compound 2; then compounds 1 and 3 (each within the scatter of the next).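

Within the data shown here, compound 1 and compound 3 form the first pair that differs in one place only, so this is the first change that can be read on its own. In this assay the exchange of methyl for hydrogen gives a 1.1-fold higher number from compound 1 to compound 3 (0.04 log units; within the scatter) and thus leaves the two compounds indistinguishable on this read-out. At this one position on the aromatic ring, in this single pair, the methyl therefore makes no measurable difference to the cytotoxic effect, and both compounds stay at the weak end of the numbers seen so far. No accompanying measurement bears on this result.

One pair cannot show whether this position is insensitive to every group, since a chlorine atom, an amine or a carboxylic acid in the same place might behave differently from methyl and hydrogen. It also remains open whether the amide substituent or the aryl group accounts for the much lower number of compound 2, as no compound shown separates those two changes.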